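The compounds below may be only part of what the source reports. "The series", "measured", "known", "first", "only" and "open" are said of these compounds alone.

Within the data shown here, in an ADME assay on LLC-MK2 cells (Macaca mulatta) for cytotoxicity, read by spectrophotometry and crystal violet staining, with a stated time of 4 days (a higher number here means that more compound is tolerated, a lower number that less compound is tolerated), compound 1 `CC(C)n1ncc2c(C(=O)Nc3cccc(C(N)=O)c3)cc(-c3cccs3)nc21` gives 25000 nM, the lower of the two numbers so far, and compound 2 `CC(C)n1ncc2c(C(=O)Nc3ncccn3)cc(-c3cccs3)nc21` gives 75000 nM. Compound 3 `CC(C)n1ncc2c(C(=O)Nc3cccc(S(=O)(=O)N(C)C)c3)cc(-c3cccs3)nc21` keeps the core of compound 1 but has dimethylsulfamoyl in place of carbamoyl on an aromatic carbon. Among the measured compounds shown here, the only measured step, a 3.0-fold higher number from compound 1 to compound 2 (0.48 log units; beyond the scatter), is modest and replaces more than this group, so it bears on the change only loosely. No clear direction follows from it, and the expected step, a 1.2-fold higher number from compound 1 to compound 3 (0.08 log units; within the scatter), stays within the scatter in this assay. Compound 3 is estimated at 30000 nM, with an expected range of 12000 nM to 75000 nM.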

Compound 3, half-maximal cytotoxic concentration: > 200000 nM
Compound 3: only a limit was reported; the forecaster's own chance of this, stated with the estimate: 15%; at least 6.6-fold (0.82 log units) between middle value and limit.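

In this assay, among these compounds, this is the first step that changes only the group on this aromatic carbon, meta to a large group: dimethylsulfamoyl in place of carbamoyl gives an at least 8.0-fold higher number from compound 1 to compound 3 (0.90 log units; beyond the scatter). The step to compound 2 replaced more than this group, so it could not show that this single change moves the number beyond the scatter. For compound 3 the reported value is a limit of the assay and not a number: the limit of > 200000 nM in this assay, at which 1 of the 3 values shown sits.

The compounds shown leave open whether the sulfonyl part or the two methyl groups on nitrogen account for the step. An unsubstituted sulfamoyl, a methylsulfonyl or a carboxylic acid on this carbon would bear on that.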